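The compounds below may be only part of what the source reports. "The series", "measured", "known", "first", "only" and "open" are said of these compounds alone.

Among the compounds with values here, compound 1 `COc1ccc(C2=C(c3ccc(SC)cc3)CC3CCCN3C2=O)cc1Br` is one of two compounds measured in a functional assay on MCF-A cells (Homo sapiens) for cytotoxicity (a higher number here means a weaker inhibitor of growth, a lower number a stronger inhibitor of growth), where compound 1 gives 6000 nM, the highest of the two numbers. Compound 2 `CSc1ccc(C2=C(c3ccc(C)cc3)C(=O)N3CCCC3C2)cc1` gives 600 nM in this assay; the step of a 10-fold lower number from compound 1 to compound 2 (1.00 log units; beyond the scatter) came with 4-methylphenyl in place of 3-bromo-4-methoxyphenyl on a double-bonded ring carbon. Compound 3 `CSc1ccc(C2=C(c3ccc(SC)cc3)C(=O)N3CCCC3C2)cc1` differs from compound 1 by 4-(methylsulfanyl)phenyl in place of 3-bromo-4-methoxyphenyl on a double-bonded ring carbon. Within the data shown here, only that one step bears on this change, since it replaces the same group at the same place; a lower number of about the same size is therefore expected in this assay, giving an 8.6-fold lower number from compound 1 to compound 3 (0.93 log units; beyond the scatter). Compound 3 is estimated at 700 nM, with a range from 200 nM to 2500 nM.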

Compound 3, concentration for 50% growth inhibition: 8000 nM
Estimate against measurement, compound 3: 11-fold (1.06 log units) below, and the stated range ends below it.
By their numbers in this assay, from the lowest: compound 2; then compounds 1 and 3 (each within the scatter of the next).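

In this assay, the step of a 1.3-fold higher number from compound 1 to compound 3 (0.12 log units; within the scatter) puts 4-(methylsulfanyl)phenyl and 3-bromo-4-methoxyphenyl on a level at this double-bonded ring carbon, so the gain seen with 4-methylphenyl does not extend to every replacement here. The step of a 13-fold higher number from compound 2 to compound 3 (1.12 log units; beyond the scatter) with methylsulfanyl in place of methyl shows that this single aromatic substituent decides the result. Nothing measured here accounts for this difference. From the compounds shown here alone, whether an ethyl group, a chlorine atom or an amine on that aromatic carbon would stay near compound 2 remains open.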